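The source may report more compounds than this note shows. Statements on the series, on what has been measured and on what is new or still open speak of the compounds shown alone.

Working notes on the series.

Compound 1 `CC(C(=O)NCc1ccc(C(F)(F)F)nc1Cl)c1ccc(NS(C)(=O)=O)c(F)c1` gives 0.2 nM in an assay on CHO cells for antagonist activity at transient receptor potential cation channel subfamily V member 1 (Homo sapiens), read by FLIPR and calcium flux; a lower number here means a stronger inhibitor, a higher number a weaker inhibitor. Compound 2 `CCCCCCc1nc(C(F)(F)F)ccc1CNC(=O)C(C)c1ccc(NS(C)(=O)=O)c(F)c1` gives 1.6 nM, and compound 3 `CC(C(=O)NCc1ccc(C(F)(F)F)nc1C1CCC(F)(F)CC1)c1ccc(NS(C)(=O)=O)c(F)c1` gives 1.5 nM. On these three numbers compound 3 stands second highest: it sits within the scatter of compound 2, the step of a 1.1-fold lower number from compound 2 to compound 3 (0.03 log units; within the scatter), and furthest from compound 1, the step of a 7.5-fold higher number from compound 1 to compound 3 (0.88 log units; beyond the scatter). The two steps out of compound 1, an 8.0-fold higher number from compound 1 to compound 2 (0.90 log units; beyond the scatter) and a 7.5-fold higher number from compound 1 to compound 3 (0.88 log units; beyond the scatter), are of modest and near-equal size, so a hexyl chain and a 4,4-difluorocyclohexyl ring at this aromatic carbon, next to the ring nitrogen, have so far been interchangeable.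

Compound 4 `CC(C(=O)NCc1ccc(C(F)(F)F)nc1C1=C[C@H](C)CCC1)c1ccc(NS(C)(=O)=O)c(F)c1` carries the change (3-methylcyclohex-1-en-1-yl in place of 4,4-difluorocyclohexyl on an aromatic carbon). Within the data shown here, no measured step swaps one six-membered non-aromatic ring for another here; the nearest comparison is the swap of hexyl for 4,4-difluorocyclohexyl, which gave a 1.1-fold lower number from compound 2 to compound 3 (0.03 log units; within the scatter). Both rings are of similar size with no donors or acceptors, so for compound 4 a step of no change at the digits printed from compound 3 to compound 4 (within the scatter) is expected in this assay, not beyond the scatter. Compound 4 is therefore estimated at 1.5 nM, within a range of 0.5 nM to 4.5 nM.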

Compound 4, inhibition constant: 0.1 nM
Compound 4: middle estimate off by 15-fold (1.18 log units), on the high side; measured number below the stated range.
By their numbers in this assay, from the lowest: compounds 4 and 1 (each within the scatter of the next); then compounds 3 and 2 (each within the scatter of the next).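

At this aromatic carbon, the presence of one six-membered non-aromatic ring of carbon only does not settle the number in this assay: a 15-fold lower number from compound 3 to compound 4 (1.18 log units; beyond the scatter) is large, and a 16-fold lower number from compound 2 to compound 4 (1.20 log units; beyond the scatter) is of like size, so the earlier match between hexyl and 4,4-difluorocyclohexyl does not extend to 3-methylcyclohex-1-en-1-yl. Against chloro, a 2.0-fold lower number from compound 1 to compound 4 (0.30 log units; within the scatter) leaves the two groups indistinguishable, so a group as large as this ring can give a number that matches the chloro compound. Nothing at hand explains the difference between the two rings.

Still open, going by these compounds, is how a plain cyclohexyl or a cyclohex-1-en-1-yl ring without the methyl would read here, which would separate the double bond from the methyl. On these data alone, the opposite configuration at the defined stereocentre and a piperidinyl ring, which carries an amine, also remain open.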